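This account rests on a few compounds, and the source may have more. Where it says the series, first, only, none or still open, it means among the compounds named here.

Measured so far in an ADME assay on HEp-2 cells (Homo sapiens) for cytotoxicity, read by CCK-8 assay, with a stated time of 6 days; on this read-out lower numbers stand for higher toxicity in this test and higher numbers for lower toxicity in this test:

- compound 1 `CCc1ccn2c(CCCCO)c(Cn3c(=O)n(C4CC4)c4ccncc43)nc2c1` gives > 100000 nM
- compound 2 `O=C(NCCO)c1c(Cn2c(=O)n(C3CC3)c3ccncc32)nc2cc(Cl)ccn12` gives > 100000 nM

For compound 2 the reading in this assay is a limit of the assay and not a number. The reading for compound 1 is likewise a limit. Both readings sit at the same point, namely (the limit of > 100000 nM in this assay, at which 2 of the 2 values shown sit), so neither a gap between them nor any direction can be read off. For the measured compounds named here, no step between measured compounds that differ in one place is available in this assay.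

Compound 3 `CCCCNc1c(Cn2c(=O)n(C3CC3)c3ccncc32)nc2cc(Cl)ccn12` arises from compound 2 through one change: butylamino in place of (2-hydroxyethyl)carbamoyl on an aromatic carbon. With only limits on hand, nothing in the series points to a shift beyond the scatter, and the expected step that the limit leaves unreadable from compound 2 to compound 3 is taken as none beyond the scatter. Compound 3 is accordingly estimated at 120000 nM, with a range from 40000 nM to 300000 nM, most likely again reported only as a limit.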

Compound 3, half-maximal cytotoxic concentration: > 100000 nM
Compound 3: only a limit was reported; the forecaster's own chance of this, stated with the estimate: 75%; the middle value is on the limit's open side.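

No step can be read between compound 2 and compound 3 in this assay, as both readings are limits of the assay and not numbers: the limit of > 100000 nM in this assay, at which 3 of the 3 values shown sit. The compounds shown leave open at what concentration, if any, each would give a readable half-maximal cytotoxic value.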